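A few compounds are considered here, and "the series" means these few. Any claim that something is new, unique, unknown or untested is made for them only; others in the source may bear on it.

Measured compounds:
- compound 1, `N[C@H]1CC[C@H](Nc2c(C(=O)NCc3ccc(Cl)cc3)nc(Br)c3cccnc23)CC1`: 4000 nM
- compound 2, `N[C@H]1CC[C@H](Nc2c(C(=O)NCc3ccc(Oc4ccccc4)cc3)nc(Br)c3cccnc23)CC1`: "not determined" (no result reported)
- compound 3, `NCCNc1c(C(=O)NCc2ccc(F)cc2)nc(Br)c2cccnc12`: > 20000 nM

Three compounds built on the shared core were tested in a functional assay on HCT-116 cells (Homo sapiens) for cytotoxicity, read by MTT assay, with a stated time of 72 h; on this read-out lower numbers stand for stronger inhibition and higher numbers for weaker inhibition. Among the compounds with values here, compound 1 gives 4000 nM, the only plain number among the three. For compound 3 the result is the limit of > 20000 nM in this assay, at which 1 of the 3 values shown sits, a limit of this assay rather than a number. For compound 2 no result is reported in this assay. Since no two of the measured compounds differ in a single place, nothing more can be said of compound 1 and compound 3 than what their two values show.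

Compound 4, `C[C@H](NC(=O)c1nc(Br)c2cccnc2c1N[C@H]1CC[C@H](N)CC1)c1ccc(F)cc1`, differs from compound 1 by 1-(4-fluorophenyl)ethyl in place of 4-chlorobenzyl on an amide-type nitrogen. The step from compound 1 to compound 4 is expected to be a 1.4-fold higher number from compound 1 to compound 4 (0.14 log units; within the scatter), that is, small and probably within the usual scatter, with a slight lean toward weaker inhibition. Compound 4 is therefore estimated at 5500 nM, within a range from 1500 nM to 20000 nM.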

Compound 4, half-maximal inhibitory concentration: > 10000 nM
Compound 4 gave a limit, no number; the forecaster's own chance of this, stated with the estimate: 25%; middle value at least 1.8-fold (0.25 log units) away from the limit.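

In this assay, within the data shown here, 1-(4-fluorophenyl)ethyl in place of 4-chlorobenzyl on an amide-type nitrogen gives an at least 2.5-fold higher number from compound 1 to compound 4 (0.39 log units; beyond the scatter), the first step that can be read and one that lies beyond the scatter. It shows that inhibition at this position is sensitive to the group on this nitrogen, since this change weakens it. Compound 4 gives a limit of the assay, not a number, so the full size of the step stays unknown: the limit of > 10000 nM in this assay, at which 1 of the 4 values shown sits.

The change swaps chlorine for fluorine and adds a defined stereocentre at the same time, so the compounds shown do not tell which of these carries the loss. As far as these compounds go, a 1-(4-chlorophenyl)ethyl group on the same nitrogen would separate the two, and how it would read remains open.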